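Solubility at Low pH Across a Nitro-Substituted Series

The source may report more compounds than this note shows. Statements on the series, on what has been measured and on what is new or still open speak of the compounds shown alone.

Measured compounds in a physicochemical assay for solubility, read by HPLC, with a stated time of 12 h, at pH 2; a higher number here means a more soluble compound, a lower number a less soluble compound:
- compound 1 `O=c1nc(N2CCN(CC3CCCCC3)CC2)sc2c([N+](=O)[O-])cc(C(F)(F)F)cc12`: 0.9 ug/mL
- compound 2 `O=c1nc(N2CCC3(CCN(Cc4ccccc4)C3)CC2)sc2c([N+](=O)[O-])cc(C(F)(F)F)cc12`: 1.56 ug/mL
- compound 3 `O=c1nc(N2CCC3(CCN(Cc4ccc(C(F)(F)F)cc4)CC3)CC2)sc2c([N+](=O)[O-])cc(C(F)(F)F)cc12`: 1.24 ug/mL

Three compounds share the core and differ in the amine attached to it. Compound 1 carries a cyclohexylmethyl piperazine, while compound 2 and compound 3 carry spirocyclic amines bearing a benzyl or a 4-(trifluoromethyl)benzyl group. In this assay compound 2 gives the largest number of the three, yet the gaps to compound 3 and to compound 1 both lie within the scatter, so no ordering among the three can be read from these numbers; all three sit in the same low range.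

The next compound, compound 4 `COc1ccc(CN2CCC3(CCN(c4nc(=O)c5cc(C(F)(F)F)cc([N+](=O)[O-])c5s4)CC3)C2)cc1`, is not yet measured. Relative to compound 2 the change is methoxy in place of hydrogen on an aromatic carbon. For the measured compounds named here, no measured pair in this set isolates that change, so the expectation rests only on the three values above, which sit close together regardless of the amine.

For compound 4 a step in this assay of a 1.1-fold lower number from compound 2 to compound 4 (0.05 log units; within the scatter) is expected, which is no step beyond the scatter, in no firm direction. The estimate for compound 4 is 1.4 ug/mL, with a range from 0.6 ug/mL to 3.5 ug/mL.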

Compound 4, solubility: 1.4 ug/mL
Compound 4: the middle estimate sits on the measured number at the digits printed, and the stated range covers the measured number.
By their numbers in this assay, from the lowest: compounds 1, 3, 4 and 2 (each within the scatter of the next).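

For the compounds shown here, compound 2 and compound 4 form the first pair that differs in one place, so a single change can now be read directly. In this assay, methoxy in place of hydrogen on an aromatic carbon, para to a large group, gives a 1.1-fold lower number from compound 2 to compound 4 (0.05 log units; within the scatter). At this place on the six-membered aromatic ring of carbon only, benzyl to 4-methoxybenzyl therefore produces no step beyond the scatter, and the added oxygen and carbon leave compound 4 in the same low range as compound 2; no measurement shown bears on the reason for this result.

Going by these compounds alone, this single pair covers only one group at one place on one amine, so it gives no general rule for the ring or for the series. As far as these compounds go, whether a carboxylic acid or a dimethylamino group at the same place would give a step beyond the scatter in this assay remains open, as does whether methoxy would give the same small step on the benzyl group of a different amine.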